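Fluorine Moved to Another Place on the Phenyl

This account rests on a few compounds, and the source may have more. Where it says the series, first, only, none or still open, it means among the compounds named here.

Compound 1 `CNC(=O)c1cc(Oc2ccc(NC(=O)c3cc4cccnc4n(-c4ccccc4)c3=O)cc2)ccn1` gives the lowest of the two numbers measured in a functional assay on NCI-H460 cells (Homo sapiens) for antiproliferative activity, read by MTT assay, with a stated time of 72 h (on this read-out lower numbers stand for stronger inhibition and higher numbers for weaker inhibition), at 320 nM. Its nearest neighbour, compound 2 `CNC(=O)c1cc(Oc2ccc(NC(=O)c3cc4cccnc4n(-c4ccccc4F)c3=O)cc2)ccn1`, gives 590 nM in this assay; the step of a 1.8-fold higher number from compound 1 to compound 2 (0.27 log units; within the scatter) put a fluoro in place of hydrogen on an aromatic carbon. Compound 3 `CNC(=O)c1cc(Oc2ccc(NC(=O)c3cc4cccnc4n(-c4ccc(F)cc4)c3=O)cc2)ccn1` carries the same kind of change at a different place: fluoro in place of hydrogen on an aromatic carbon, para to a large group, reading phenyl to 4-fluorophenyl. Going by the values given here, the one step that bears on it stayed within the scatter, so the expected step of a 1.3-fold higher number from compound 1 to compound 3 (0.10 log units; within the scatter) is small. Compound 3 is estimated at 400 nM, between 150 nM and 1100 nM.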

Compound 3, half-maximal inhibitory concentration: 210 nM
Compound 3: the middle estimate sits 1.9-fold (0.28 log units) above what was measured; measured number inside the range.
By their numbers in this assay, from the lowest: compounds 3, 1 and 2 (each within the scatter of the next, the first and the last beyond it).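

In this assay the place of the fluoro on the phenyl separates two compounds where its mere presence does not: moving it gives a 2.8-fold lower number from compound 2 to compound 3 (0.45 log units; beyond the scatter), whereas adding it at this position gives a 1.5-fold lower number from compound 1 to compound 3 (0.18 log units; within the scatter). Compound 1 thus stands within the scatter of both fluorinated compounds, which stand apart only from each other. Nothing at hand explains this difference.

Open, going by these compounds, is how a chloro, methoxy or amine group would read in the place of this fluoro, and how a second fluoro on the phenyl would read.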